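Series notes: carbamoyl variant of the nitro chromene thioamide

The source may report more compounds than this note shows. Statements on the series, on what has been measured and on what is new or still open speak of the compounds shown alone.

Measured so far in a functional assay on the whole organism (aorta) with Rattus norvegicus as the target; on this read-out higher numbers stand for larger maximal responses and lower numbers for smaller maximal responses:
- compound 1 `CC1(C(F)(F)F)C=C(/C(S)=N\CCC#N)c2cc([N+](=O)[O-])ccc2O1`: 69.7%
- compound 2 `N#CCC/N=C(/S)C1=CC(C(F)(F)F)(C(F)(F)F)Oc2ccc([N+](=O)[O-])cc21`: 74.8%

Compound 1 gives the lowest of the two numbers in this assay; the nearest is compound 2, and the step of a number 5.1 percentage points higher from compound 1 to compound 2 (within the scatter) lies within the scatter. That step changes a methyl to a trifluoromethyl on a saturated ring carbon and says nothing about the side chain on the double-bonded ring carbon.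

Compound 3 `CC1(C(F)(F)F)C=C(C(=O)NCCC#N)c2cc([N+](=O)[O-])ccc2O1` is not yet measured. It differs from compound 1 in that (a group of 7 heavy atoms (4 carbon, 2 nitrogen, 1 oxygen; no ring) in place of a group of 7 heavy atoms (4 carbon, 2 nitrogen, 1 sulfur; no ring), on a double-bonded ring carbon). Among the measured compounds shown here, no measured pair touches this place: the only step available, from compound 1 to compound 2, sits elsewhere in the core, so there is no measured guide for replacing the sulfur-bearing group by the (2-cyanoethyl)carbamoyl group.

With nothing to set the direction, the expected step of a number 7.7 percentage points lower from compound 1 to compound 3 (within the scatter) is taken as close to none, with a wide band around it. Compound 3 is therefore estimated at 62% in this assay, within a range from 35% to 85%.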

Compound 3, intrinsic activity: the largest response reached, in percent of the reference agonist's: 70.6%
Estimate against measurement, compound 3: 8.6 percentage points below; measured number inside the range.
By their numbers in this assay, from the lowest: compounds 1, 3 and 2 (each within the scatter of the next).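

In this assay, the group on the double-bonded ring carbon now has a measured step: the (2-cyanoethyl)carbamoyl group in place of the sulfur-bearing group gives a number 0.9 percentage points higher from compound 1 to compound 3 (within the scatter). With the methyl and trifluoromethyl groups of compound 1 held fixed, replacing sulfur with oxygen in a group of the same heavy-atom and hydrogen-bond donor and acceptor counts leaves the maximal response without a readable change, so sulfur is not needed at this position for a response of this size. No measurement at hand gives a reason for this outcome.

Going by these compounds, whether the same exchange leaves the response equally unchanged on the core of compound 2, with its two trifluoromethyl groups, remains open. Also open, on these data alone, is how much of the side chain matters at this position: a longer chain in place of the 2-cyanoethyl chain, a simple methyl on the amide nitrogen, or a carboxylic acid in place of the whole carbamoyl group would test a larger change than this one.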